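Nitro in Place of Trifluoromethyl on the Carbonyl-Bearing Ring

A few compounds are considered here, and "the series" means these few. Any claim that something is new, unique, unknown or untested is made for them only; others in the source may bear on it.

Compound 1, `COc1cc(-c2nnc3n2NC(c2ccco2)C(C(=O)c2ccccc2C)S3)cc(OC)c1OC`, gives 69900 nM in a functional assay on MCF7 cells (Homo sapiens) for cytotoxicity, read by MTT assay, with a stated time of 48 h; on this read-out lower numbers stand for stronger inhibition and higher numbers for weaker inhibition.
Compound 2, `COc1cc(-c2nnc3n2NC(c2ccco2)C(C(=O)c2ccc(Cl)cc2)S3)cc(OC)c1OC`, reaches only a limit of the assay, > 100000 nM.
Compound 3, `COc1cc(-c2nnc3n2NC(c2ccco2)C(C(=O)c2ccc(C(F)(F)F)cc2)S3)cc(OC)c1OC`, gives 33600 nM.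

Within this small set compound 3 stands at the lowest of the two numbers that are not limits; its nearest neighbour is compound 1, and the step of a 2.1-fold lower number from compound 1 to compound 3 (0.32 log units; beyond the scatter) lies beyond the scatter. The other measured step, an at least 2.9-fold lower number from compound 2 to compound 3 (0.47 log units; beyond the scatter), is at least modest but rests on a limit for compound 2 (the limit of > 100000 nM in this assay, at which 1 of the 3 values shown sits).

Compound 4, `COc1cc(-c2nnc3n2NC(c2ccco2)C(C(=O)c2ccc([N+](=O)[O-])cc2)S3)cc(OC)c1OC`, differs from compound 3 by nitro in place of trifluoromethyl on an aromatic carbon. Both measured steps concern the same group on the same ring, yet neither involves a nitro group, so they only show that swapping this substituent moves the number by a modest amount in either direction. Compound 4 is therefore expected to land near compound 3, with a 1.3-fold higher number from compound 3 to compound 4 (0.13 log units; within the scatter), at an estimated 45000 nM, in a range from 15000 nM to 120000 nM.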

Compound 4, half-maximal inhibitory concentration: > 100000 nM
Compound 4 was reported as a limit (the forecaster's own chance of this, stated with the estimate: 25%); middle value at least 2.2-fold (0.34 log units) from the limit.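

At this place on the ring, the result shows that the number depends on which group is present: nitro in place of trifluoromethyl gives an at least 2.9-fold higher number from compound 3 to compound 4 (0.47 log units; beyond the scatter). Chloro and nitro now both end at a limit, so among the three groups at this place, only trifluoromethyl, in compound 3, gives a value that is not a limit. Against compound 1, the change gives an at least 1.4-fold higher number from compound 1 to compound 4 (0.15 log units; that floor lies within the scatter), and that floor does not separate the two compounds beyond the scatter.

The step between compound 2 and compound 4 cannot be read, since both values are limits: the limit of > 100000 nM in this assay, at which 2 of the 4 values shown sit. Going by these compounds, whether an amine, a carboxylic acid or a longer chain at this place would give a number below that limit remains open.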